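Cyclopropyl for methyl on the ring nitrogen of compound 1

A few compounds are considered here, and "the series" means these few. Any claim that something is new, unique, unknown or untested is made for them only; others in the source may bear on it.

In an ADME assay on BaF3 cells (Mus musculus) for inhibition, read by CellTiter-Glo, with a stated time of 72 h (on this read-out higher numbers stand for weaker inhibition of growth and lower numbers for stronger inhibition of growth), compound 1 (`Cc1ccc(Nc2ncc3c(n2)N(C)C(=O)N(c2cc(NC(=O)c4ccc(C)c(C(F)(F)F)c4)ccc2C)C3)cn1`) gives 870 nM, the middle of three numbers. Compound 2 (`Cc1ccc(Nc2ncc3c(n2)N(C)C(=O)N(c2cc(NC(=O)c4ccccc4)ccc2C)C3)cn1`) gives 2700 nM and compound 3 (`Cc1ccc(Nc2ncc3c(n2)N(C)C(=O)N(c2cc(NC(=O)c4ccc(-n5cccc5)c(C(F)(F)F)c4)ccc2C)C3)cn1`) gives 317 nM. The measured changes are both modest and both lie on the group carried by the carbonyl carbon: a 3.1-fold higher number from compound 1 to compound 2 (0.49 log units; beyond the scatter) and a 2.7-fold lower number from compound 1 to compound 3 (0.44 log units; beyond the scatter). Compound 4 (`Cc1ccc(Nc2ncc3c(n2)N(C2CC2)C(=O)N(c2cc(NC(=O)c4ccc(C)c(C(F)(F)F)c4)ccc2C)C3)cn1`) instead has cyclopropyl in place of methyl on an amide-type nitrogen in a ring. Within the data shown here, no measured step covers this place, so neither the size nor the direction is firmly grounded. The expected step is a 1.0-fold higher number from compound 1 to compound 4 (0.01 log units; within the scatter), which is no clear change. For compound 4 the estimated value is 900 nM, within an expected range of 320 nM to 2500 nM.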

Compound 4, concentration for 50% growth inhibition: 649 nM
Compound 4: middle estimate off by 1.4-fold (0.14 log units), on the high side; measured number inside the range.
By their numbers in this assay, from the lowest: compound 3; then compounds 4 and 1 (each within the scatter of the next); then compound 2.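

In this assay the amide-type ring nitrogen takes cyclopropyl in place of methyl with a 1.3-fold lower number from compound 1 to compound 4 (0.13 log units; within the scatter), so a three-membered ring fits at this position without a change beyond the scatter. Among these compounds, the earlier steps all lay on the group carried by the carbonyl carbon, so this is the first reading at this nitrogen. No measurement on these compounds offers an explanation for this result. Still open, as far as these compounds go, is how a longer chain or an amine on this nitrogen would read, and whether cyclopropyl here gives the same result with the carbonyl-side groups of compound 2 or compound 3.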